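The source may report more compounds than this note shows. Statements on the series, on what has been measured and on what is new or still open speak of the compounds shown alone.

Three compounds share a core built around a small ester-bearing ring; each has been tested in a functional assay on NPC-TW01 cells (Homo sapiens) for inhibition, read by MTT assay, with a stated time of 72 h; on this read-out higher numbers stand for weaker inhibition of growth and lower numbers for stronger inhibition of growth. Compound 1, `COC(=O)c1nc(-c2ccsc2)n(-c2ccc(F)cc2)n1`, gives 10700 nM in this assay. Compound 2, `COC(=O)c1nc(-c2ccsc2)n(-c2ccc(C(F)(F)F)cc2)n1`, gives 34900 nM. The two differ only by fluoro in place of trifluoromethyl on an aromatic carbon, and that change gave a 3.3-fold lower number from compound 2 to compound 1 (0.51 log units; beyond the scatter). Compound 3, `CCOC(=O)c1nc(-c2ccc[nH]2)n(-c2ccc(C(F)(F)F)cc2)n1`, gives 76400 nM, the highest of the three numbers. The difference between the core of compound 3 and the core of compound 2 is not broken down here.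

Compound 4, `CCOC(=O)c1nc(-c2ccc[nH]2)n(-c2ccc(F)cc2)n1`, has not yet been tested. It differs from compound 3 by fluoro in place of trifluoromethyl on an aromatic carbon, the same change, at the same kind of place, that separates compound 2 from compound 1. Since that change lowered the number in this assay by a 3.3-fold lower number from compound 2 to compound 1 (0.51 log units; beyond the scatter), a step of similar size is expected from compound 3 to compound 4, namely a 3.3-fold lower number from compound 3 to compound 4 (0.52 log units; beyond the scatter). Resting on this single earlier example, compound 4 is estimated to give about 23000 nM in this assay, most likely between 9000 nM and 55000 nM.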

Compound 4, concentration for 50% growth inhibition: 64300 nM
Estimate against measurement, compound 4: 2.8-fold (0.45 log units) below; the measured number lies above the stated range.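

In this assay, putting fluoro in place of trifluoromethyl on the second core gave a 1.2-fold lower number from compound 3 to compound 4 (0.07 log units; within the scatter), so on that core the swap has no effect that can be told from ordinary repeat-to-repeat variation. The change therefore did not carry over at the same size from one core to the other: the same change on two cores in this assay, a 3.3-fold lower number (0.51 log units; beyond the scatter) from compound 2 to compound 1 and a 1.2-fold lower number (0.07 log units; within the scatter) from compound 3 to compound 4, 2.7-fold (0.44 log units) apart, beyond the scatter of two such steps This shows that the size of the step depends on the core it is made on, but it does not show which part of the core matters, as the two cores differ in more than one place, and two pairs of compounds give no rule for the whole series.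

The compounds shown leave open whether the ester or the ring group on the core sets the size of the step, which a single change to either one would help to separate. They also leave open how a chloro or a methoxy group would behave at this place on the aromatic ring, and how a carboxylic acid or an amide would behave in place of the ester.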